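This account rests on a few compounds, and the source may have more. Where it says the series, first, only, none or still open, it means among the compounds named here.

Working notes on the series, read in a functional assay on MIA PaCa-2 cells (Homo sapiens) for inhibition, read by MTT assay, with a stated time of 48 h, tested at 10 uM; a lower number here means less inhibition of growth, a higher number more inhibition of growth at the concentration tested. Compound 1 (`Cc1cc(=O)c2c(O)c(CN3CCC(N4CCCCC4)CC3)c(O)c([C@H]3CCN(C)C[C@H]3O)c2o1`) gives 23%, compound 2 (`Cc1cc(=O)c2c(O)c(CN3CCCC3)c(O)c([C@H]3CCN(C)C[C@H]3O)c2o1`) gives 28% and compound 3 (`Cc1cc(=O)c2c(O)c(CN3CCCC3CO)c(O)c([C@H]3CCN(C)C[C@H]3O)c2o1`) gives 13%. Compound 1 thus lies within the scatter of both compound 2 and compound 3, although those two differ from each other by more than the scatter.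

Compound 4 (`Cc1cc(=O)c2c(O)c(CN3CCC(Cc4ccccc4)CC3)c(O)c([C@H]3CCN(C)C[C@H]3O)c2o1`) is still unmeasured. It differs from compound 1 by benzyl in place of piperidin-1-yl on a saturated ring carbon.

Within the data shown here, only one single-place step has been measured, a number 15 percentage points lower from compound 2 to compound 3 (beyond the scatter). It is modest and concerns hydroxymethyl on a different amine ring, so it bears only loosely on this change. Among the measured compounds shown here, no measured compound carries benzyl, and no step at this ring carbon has been measured. A large step therefore cannot be supported, and no shift beyond the scatter is expected in this assay, with only a slight lean upward. The expected step is a number 6 percentage points higher from compound 1 to compound 4 (within the scatter). For compound 4 the estimated value is 29%, with an expected range of 12% to 50%.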

Compound 4, percent growth inhibition at one concentration: 18%
Compound 4: the middle estimate sits 11 percentage points above what was measured; the measured number falls inside the stated range.
By their numbers in this assay, from the lowest: compounds 3, 4, 1 and 2 (each within the scatter of the next, the first and the last beyond it).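

Read in this assay, the exchange of piperidin-1-yl for benzyl on a saturated ring carbon, three ring bonds from the ring nitrogen, gives a number 5 percentage points lower from compound 1 to compound 4 (within the scatter) and is the first step read at this ring carbon. At this place, a six-membered aromatic ring of carbon only, carried as benzyl, can thus stand in for a six-membered non-aromatic ring with a nitrogen without a shift beyond the scatter. No measurement in hand offers an explanation for this result.

From the compounds shown here alone, whether a carboxylic acid, a primary amine or a longer chain such as 2-phenylethyl on this ring carbon would move the number beyond the scatter remains open. Also open, going by these compounds, is whether a substituted benzyl, such as 4-fluorobenzyl, would stay within the scatter of benzyl.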